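Dichlorophenyl Substitution on a Thiazole Acylurea Hydrazone Series

A few compounds are considered here, and "the series" means these few. Any claim that something is new, unique, unknown or untested is made for them only; others in the source may bear on it.

Measured compounds:
Compound 1, `CN(C(=O)NC(=O)c1ccc(Cl)c(Cl)c1)c1nc(C(F)(F)F)c(C(=O)N/N=C/c2ccc([N+](=O)[O-])cc2)s1`, 5.12 ug/mL
Compound 2, `CN(C(=O)NC(=O)c1ccccc1)c1nc(C(F)(F)F)c(C(=O)N/N=C/c2cccc([N+](=O)[O-])c2)s1`, 11.2 ug/mL

In a functional assay on HeLa cells (Homo sapiens) for inhibition, read by MTT assay, with a stated time of 72 h (a lower number here means a stronger inhibitor, a higher number a weaker inhibitor), compound 2 stands at the highest of the two numbers recorded so far. Among the compounds with values here, its only neighbour, compound 1, gives 5.12 ug/mL, a gap that lies beyond the scatter of repeated measurements. Within the data shown here, the two compounds differ in two places at once, so their values show only that compound 1 is the stronger of the pair.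

Compound 3, `CN(C(=O)NC(=O)c1ccc(Cl)c(Cl)c1)c1nc(C(F)(F)F)c(C(=O)N/N=C/c2cccc([N+](=O)[O-])c2)s1`, has not yet been measured. It differs from compound 2 by a single change, (3,4-dichlorophenyl in place of phenyl on a carbonyl carbon). Compound 3 therefore shares the 3,4-dichlorophenyl group of compound 1 and the rest of its structure with compound 2.

Among the measured compounds shown here, no single-change step is yet known, so the expected size of the step is uncertain. Compound 3 is expected to give a lower number than compound 2 in this assay, because compound 1, which carries the same 3,4-dichlorophenyl group, gives 5.12 ug/mL. The expected step is a 1.7-fold lower number from compound 2 to compound 3 (0.24 log units; within the scatter). For compound 3 the estimate in this assay is 6.5 ug/mL, within a range from 2.8 ug/mL to 14 ug/mL.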

Compound 3, half-maximal inhibitory concentration: 6.56 ug/mL
Compound 3: middle estimate off by 1.0-fold (0.00 log units), on the low side; the measured number falls inside the stated range.
By their numbers in this assay, from the lowest: compounds 1, 3 and 2 (each within the scatter of the next, the first and the last beyond it).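

In this assay the series now has its first steps that change one place only. Putting 3,4-dichlorophenyl in place of phenyl on a carbonyl carbon gives a 1.7-fold lower number from compound 2 to compound 3 (0.23 log units; within the scatter) and so, with the rest of the structure held constant, the two chlorine atoms leave a difference that cannot be told from the scatter. Putting 3-nitrophenyl in place of 4-nitrophenyl on a carbon with a double bond to nitrogen gives a 1.3-fold higher number from compound 1 to compound 3 (0.11 log units; within the scatter) and is equally unresolved, while no measurement is available that could account for either step.

Within the data shown here, each of these two places has been explored with only one change, so it remains open whether an amine or a carboxylic acid on the phenyl ring of the benzoyl group would give a step beyond the scatter. The trifluoromethyl group is common to all three compounds, which leaves unknown what a methyl group or a carboxylic acid in its place would do.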